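The source may hold more compounds than are shown below. What is called first, only, known or untested is meant among the compounds shown, and "the series" means these compounds.

Measured compounds:
- compound 1, `COc1ccc(-c2cnc3nc(N)nc(N4CCN(Cc5ccccc5F)CC4)c3n2)cc1OC`: 700 nM
- compound 2, `COc1ccc(-c2cnc3nc(N)nc(N4CCN(C(=O)Nc5cccc(C)c5)CC4)c3n2)cc1OC`: 7 nM
- compound 3, `CCOc1nc(N)nc2ncc(-c3cccc(OC)c3)nc12`: 8300 nM

All three were tested in a functional assay on cells (T-cell, Homo sapiens) for inhibition; on this read-out lower numbers stand for stronger inhibition and higher numbers for weaker inhibition. Compound 2 gives the lowest number of the three. Its nearest neighbour is compound 1: the step of a 100-fold lower number from compound 1 to compound 2 (2.00 log units; beyond the scatter) came with (3-methylphenyl)carbamoyl in place of 2-fluorobenzyl on the amine nitrogen in the ring. Compound 3, which carries a different core substitution pattern, sits far higher still, at 8300 nM.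

Compound 4, `COc1ccc(-c2cnc3nc(N)nc(N4CCN(C(=O)Nc5ccc(F)cc5)CC4)c3n2)cc1OC`, has not yet been measured. It differs from compound 2 only in the aryl group attached to the amide-type nitrogen: 4-fluorophenyl in place of 3-methylphenyl on an amide-type nitrogen

Among the compounds with values here, the only measured step, a 100-fold lower number from compound 1 to compound 2 (2.00 log units; beyond the scatter), exchanged the whole group on the ring amine and so says nothing about swapping one aryl group for another of the same size on the amide-type nitrogen. Within the data shown here, no measured pair varies that aryl group. Without such a comparison, the expectation is for no step beyond the scatter, a 1.4-fold higher number from compound 2 to compound 4 (0.15 log units; within the scatter). Compound 4 is therefore estimated at 10 nM, with a range from 3 nM to 35 nM.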

Compound 4, half-maximal inhibitory concentration: 7 nM
The estimate for compound 4 lay 1.4-fold (0.15 log units) above the measured number, within the range that was stated.
By their numbers in this assay, from the lowest: compounds 2 and 4 (each within the scatter of the next); then compound 1; then compound 3.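

In this assay, putting 4-fluorophenyl in place of 3-methylphenyl on the amide-type nitrogen gave no change at the digits printed from compound 2 to compound 4 (within the scatter) and so showed that these two aryl groups read alike at this position. The large gain over the benzyl compound also appears with the new aryl group, as (4-fluorophenyl)carbamoyl in place of 2-fluorobenzyl gave a 100-fold lower number from compound 1 to compound 4 (2.00 log units; beyond the scatter) and so the gain is now seen with two carbamoyl groups rather than one. No measurement here explains why the two aryl groups read alike.

This swap changed the substituent and its place on the ring together, so 4-methylphenyl and 3-fluorophenyl would be needed to separate the two changes. As far as these compounds go, it also remains open how far the tolerance extends, for example to a phenyl ring carrying a carboxylic acid or an amine, or to a plain alkyl chain.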